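The compounds below may be only part of what the source reports. "The series", "measured", "known", "first", "only" and "open" are said of these compounds alone.

Among the three compounds measured so far, compound 3 `Cc1ccc(NC(=O)CSc2ccccc2C(=O)O)cc1` stands highest in a functional assay on the whole organism (strain Swiss albino) for inhibition, with Mus musculus as the target, in the writhing test, with a stated time of 30 min, at a dose of 100 mg/kg by the intraperitoneal route (a higher number here means more inhibition at the dose given (going by the name of the read-out), a lower number less inhibition), where compound 3 gives 76.3%. The other two carry a halogen in place of its methyl: compound 1 `O=C(CSc1ccccc1C(=O)O)Nc1ccc(Cl)cc1` gives 49.7%, and compound 2 `O=C(CSc1ccccc1C(=O)O)Nc1ccc(Br)cc1` gives 9.04%. The steps between them are all beyond the scatter: a number 26.6 percentage points higher from compound 1 to compound 3 (beyond the scatter), a number 67.3 percentage points higher from compound 2 to compound 3 (beyond the scatter), and a number 40.7 percentage points lower from compound 1 to compound 2 (beyond the scatter).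

Compound 4 `COc1ccc(NC(=O)CSc2ccccc2C(=O)O)cc1` is the next compound, and it differs from compound 3 in one place: methoxy in place of methyl on an aromatic carbon. Among the measured compounds shown here, no measured step involves a methoxy group, so none bears on this change directly. What the measured steps do show is that exchanging the group on this aromatic carbon shifts the read-out strongly, in both directions, with methyl giving the highest number and bromo the lowest. The swap of methyl for methoxy is therefore expected to move the number, but its direction cannot be read from the three steps known, and the estimate is kept wide. For compound 4 the expected value is 58%, in a range from 28% to 82%, which means an expected step of a number 18.3 percentage points lower from compound 3 to compound 4 (beyond the scatter).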

Compound 4, a percentage reported as inhibition, in the whole organism at one dose (the size of the read-out at that dose, not a potency): 27.7%
For compound 4 the middle estimate is 30.3 percentage points above the measured one; measured number outside the range, below it.
By their numbers in this assay, from the lowest: compound 2; then compound 4; then compound 1; then compound 3.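

In this assay, the change from methyl to methoxy adds only an oxygen, which brings a hydrogen-bond acceptor, and it gives a number 48.6 percentage points lower from compound 3 to compound 4 (beyond the scatter); a small edit at this position can therefore remove most of the highest number in the set. Compound 4 also lands among the halogen compounds rather than near the other non-halogen compound, with a number 18.7 percentage points higher from compound 2 to compound 4 (beyond the scatter) and a number 22 percentage points lower from compound 1 to compound 4 (beyond the scatter), so the order from highest to lowest runs methyl, chloro, methoxy, bromo and does not separate halogens from non-halogens. Nothing available explains this order, as no measurement of any property of these groups accompanies the numbers.

Still open, going by these compounds, is how other groups on this aromatic carbon would fall in that order, for instance a hydroxyl, an amine, fluoro or the longer ethyl chain, which would show whether the high number is special to methyl. On these data alone, each number also comes from a single dose, so whether the same order holds at other doses, or with these groups elsewhere on the ring, remains unknown.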